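Working notes: 1H-indazol-4-yl in place of 1H-indol-5-yl

A few compounds are considered here, and "the series" means these few. Any claim that something is new, unique, unknown or untested is made for them only; others in the source may bear on it.

In a functional assay on MCF7 cells (Homo sapiens) for cytotoxicity, read by CellTiter-Glo, with a stated time of 5 days (a higher number here means a weaker inhibitor, a lower number a stronger inhibitor), compound 1 (`CC/C(=C(/c1ccc(/C=C/C(=O)O)cc1)c1ccc(NS(C)(=O)=O)cc1)c1ccccc1`) gives 2310 nM and compound 2 (`CC/C(=C(/c1ccc(/C=C/C(=O)O)cc1)c1ccc2[nH]ccc2c1)c1ccccc1`) gives 9 nM as the lower of the two values, a gap beyond the scatter. Compound 3 (`CC/C(=C(/c1ccc(/C=C/C(=O)O)cc1)c1cccc2[nH]ncc12)c1ccccc1`) has not yet been measured. It carries 1H-indazol-4-yl in place of 1H-indol-5-yl on a double-bonded chain carbon bound to an aromatic carbon and a double-bonded chain carbon. The entering group has a five-membered aromatic ring with 2 hetero atoms where the leaving group has one with 1 hetero atom. For the measured compounds named here, no measured step covers this exchange, so its size in this assay can only be estimated. The estimate takes compound 2 at 9 nM as its reference. The expected change is a 3.3-fold higher number from compound 2 to compound 3 (0.52 log units; beyond the scatter) toward a weaker inhibitor, a modest loss beyond the scatter, though the estimated range reaches back into it. Compound 3 is expected at 30 nM with an estimated range from 5 nM to 180 nM in this measurement.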

Compound 3, half-maximal inhibitory concentration: 21 nM
The estimate for compound 3 lay 1.4-fold (0.15 log units) above the measured number, within the range that was stated.
By their numbers in this assay, from the lowest: compound 2; then compound 3; then compound 1.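

In this assay, 1H-indazol-4-yl in place of 1H-indol-5-yl gives a 2.3-fold higher number from compound 2 to compound 3 (0.37 log units; beyond the scatter), so this place on the double-bonded chain carbon tolerates a second group with a five-membered aromatic ring and a six-membered aromatic ring of carbon only, at a modest cost. The printed values keep compound 3 at 21 nM in the same low range as compound 2, whereas compound 1, which has a methanesulfonamide-bearing phenyl at this place, stands at 2310 nM; the activity here therefore does not depend on the exact 1H-indol-5-yl group. No supporting measurement bears on what underlies the step, including the extra ring nitrogen and the added hydrogen-bond acceptor counted in the entering group.

For the compounds shown here, the exchange alters the ring atoms and the point of attachment together, so the single step cannot divide its size between them, and a 1H-indazol-5-yl or 1H-indol-4-yl group at this place would be needed to separate the two. Also open, on these data alone, is whether this tolerance would persist with a primary amide in place of the carboxylic acid.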